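Cyclohexylamino pyrazolopyridine amidines: cytotoxicity on fibroblasts

The compounds below may be only part of what the source reports. "The series", "measured", "known", "first", "only" and "open" are said of these compounds alone.

Compound 1 `COc1cc(Nc2nc(C(=N)Nc3ccc(N4CCN(C)CC4)cc3)cc3c(-c4ccccc4)n[nH]c23)cc(OC)c1OC` belongs to the same series, but in an ADME assay on AG1523 cells (Homo sapiens) for cytotoxicity, read by MTT assay, with a stated time of 72 h (a lower number here means a stronger inhibitor, a higher number a weaker inhibitor), compound 1 gives "not determined" (no result reported). Going by the values given here, compound 2 `N=C(Nc1ccccc1)c1cc2c(-c3ccccc3)n[nH]c2c(NC2CCCCC2)n1` is therefore the only compound with a number: in this assay compound 2 gives 4190 nM, and with a single value there is no step within the measured set against which to place it.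

Compound 3 `CN1CCN(c2ccc(NC(=N)c3cc4c(-c5ccccc5)n[nH]c4c(NC4CCCCC4)n3)cc2)CC1` differs from compound 2 in one place: 4-methylpiperazin-1-yl in place of hydrogen on an aromatic carbon. Among the compounds with values here, no measured pair shows this change, so the size of its step in this assay cannot be read from the data. The expectation for compound 3 is a step at the edge of the scatter, towards stronger inhibition, as a 1.7-fold lower number from compound 2 to compound 3 (0.22 log units; within the scatter). Compound 3 is therefore estimated at 2500 nM in this assay, with a range from 800 nM to 9000 nM.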

Compound 3, half-maximal inhibitory concentration: 12300 nM
Compound 3: the middle estimate sits 4.9-fold (0.69 log units) below what was measured; the whole stated range lies below it.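

In this assay, 4-methylpiperazin-1-yl on this aromatic carbon, para to a large group, gives a 2.9-fold higher number from compound 2 to compound 3 (0.47 log units; beyond the scatter). Going by these compounds alone, this is the first measured step, and it shows that the change moves the number towards weaker inhibition, by a modest amount but beyond the usual scatter. No measurement available here bears on the reason for this step.

Within the data shown here, the single pair cannot show whether the step belongs to the 4-methylpiperazin-1-yl group in particular or would follow from other groups on the same carbon. A morpholine ring, a piperazine without the methyl group, or a single methoxy group at this place would help separate those possibilities, and the cyclohexylamino group of compounds 2 and 3 stays constant throughout this comparison.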